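Amide series: ring amine in place of dimethylamino

The source may hold more compounds than are shown below. What is called first, only, known or untested is meant among the compounds shown, and "the series" means these compounds.

Going by the values given here, compound 2 `CN(C)c1cnc(NC(=O)[C@H](c2ccc(Cl)cc2)C(C)(C)C)s1` gives 1600 nM in a functional assay on CHO cells for agonist activity at Free fatty acid receptor 2 (Homo sapiens), read by cAMP accumulation (a higher number here means a weaker inhibitor, a lower number a stronger inhibitor), the lowest of the two numbers so far. Compound 1 `CC(C)(C)[C@H](C(=O)Nc1ncc(Cc2ccc(Cl)cc2)s1)c1ccc(Cl)cc1` gives 25000 nM in this assay. Among the compounds with values here, the single measured step, a 16-fold lower number from compound 1 to compound 2 (1.19 log units; beyond the scatter), is large. Compound 3 `CN1CCN(c2cnc(NC(=O)[C@H](c3ccc(Cl)cc3)C(C)(C)C)s2)CC1` carries 4-methylpiperazin-1-yl in place of dimethylamino on an aromatic carbon. Within the data shown here, no measured step exchanges one amine for another; the one step known concerns a different change and bears on this one only loosely. The step of a 1.6-fold higher number from compound 2 to compound 3 (0.19 log units; within the scatter) is therefore expected to be small, with the number staying close to where compound 2 stands. Compound 3 is estimated at 2500 nM, range 600 nM to 10000 nM.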

Compound 3, half-maximal inhibitory concentration: 3800 nM
Beside the measured number, compound 3's estimate is 1.5-fold (0.18 log units) below it; measured number inside the range.
By their numbers in this assay, from the lowest: compound 2; then compound 3; then compound 1.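

At the aromatic carbon next to the ring sulfur, 4-methylpiperazin-1-yl in place of dimethylamino gives a 2.4-fold higher number from compound 2 to compound 3 (0.38 log units; beyond the scatter) in this assay, a modest weakening. Measured against 4-chlorobenzyl, the ring amine still keeps much of the gain, with a 6.6-fold lower number from compound 1 to compound 3 (0.82 log units; beyond the scatter), so both amines shown stand below the 4-chlorobenzyl compound. Nothing measured here explains the difference between the two amines. Open, from the compounds shown here alone, is where a morpholine ring or a pyrrolidine ring at this carbon would fall relative to compound 2 and compound 3.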